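Trading an aryl amide for a small hydroxyethyl amide

The source may report more compounds than this note shows. Statements on the series, on what has been measured and on what is new or still open speak of the compounds shown alone.

Compound 1 `CCn1c(C(=O)NCCCN(C)C)ccc1C(CC)(CC)c1ccc(OCCC(O)(CC)CC)c(C)c1` gives 3350 nM in a functional assay on MCF7 cells (Homo sapiens) for antiproliferative activity, read by MTT assay, with a stated time of 48 h; a lower number here means a stronger inhibitor, a higher number a weaker inhibitor.
Compound 2 `CCn1c(C(=O)N(CCC#N)CCC#N)ccc1C(CC)(CC)c1ccc(OCCC(O)(CC)CC)c(C)c1` reaches only the limit of this assay, > 50000 nM.
Compound 3 `CCn1c(C(=O)Nc2cccc(C(F)(F)F)c2)ccc1C(CC)(CC)c1ccc(OCCC(O)(CC)CC)c(C)c1` likewise reaches only the limit, > 50000 nM.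

Compound 3 therefore stands among the weakest of the three shown, with no exact number of its own, as two of the three values sit at that limit (the limit of > 50000 nM in this assay, at which 2 of the 3 values shown sit). The change to compound 4 `CCn1c(C(=O)N(C)CCO)ccc1C(CC)(CC)c1ccc(OCCC(O)(CC)CC)c(C)c1` is (2-hydroxyethyl)(methyl)amino in place of (3-(trifluoromethyl)phenyl)amino on a carbonyl carbon. The measured step that bears on it runs the other way: an at least 14-fold higher number from compound 1 to compound 3 (1.17 log units; beyond the scatter). Moving back from an aromatic amide substituent to a short chain with polar atoms is expected to lower the number, though compound 2 warns that a short chain alone does not guarantee it; the step between compound 2 and compound 3 is a step that the two limits leave unreadable from compound 2 to compound 3. The expected step is an at least 3.3-fold lower number from compound 3 to compound 4 (0.52 log units; beyond the scatter), and compound 4 is estimated at 15000 nM, between 3000 nM and 60000 nM.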

Compound 4, half-maximal inhibitory concentration: 2870 nM
For compound 4 the middle estimate is 5.2-fold (0.72 log units) above the measured one; the whole stated range lies above it.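

Placed on the carbonyl carbon, (2-hydroxyethyl)(methyl)amino gives a measurable value, with an at least 17-fold lower number from compound 3 to compound 4 (1.24 log units; beyond the scatter) and an at least 17-fold lower number from compound 2 to compound 4 (1.24 log units; beyond the scatter). The (3-(dimethylamino)propyl)amino group of compound 1 is therefore not required for a measurable value at this position: the step is a 1.2-fold lower number from compound 1 to compound 4 (0.07 log units; within the scatter). The first two steps start from assay limits rather than numbers, so they show only a minimum size: the limit of > 50000 nM in this assay, at which 2 of the 4 values shown sit.

From the compounds shown here alone, whether the hydroxyl group of compound 4 matters remains open. So does the effect of a carboxylic acid, a piperazine or a longer hydroxyalkyl chain on this carbonyl carbon.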